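Cytotoxicity notes: trimming the side chain from compound 2

The source may report more compounds than this note shows. Statements on the series, on what has been measured and on what is new or still open speak of the compounds shown alone.

Measured compounds in an ADME assay on cells (Homo sapiens) for cytotoxicity; on this read-out lower numbers stand for higher toxicity in this test and higher numbers for lower toxicity in this test:
- compound 1 `O=C1N(CCC(CCOc2ccc(-c3ccc(Cl)cc3)cc2)C(F)(F)F)CCN1c1ccncc1` gives > 12500 nM, a limit of the assay
- compound 2 `CCCC(CCOc1ccc(-c2ccc(Cl)cc2)cc1)CCN1CCN(c2ccncc2)C1=O` gives > 25000 nM, a limit of the assay
- compound 3 `O=C1N(Cc2ccc(COc3ccc(-c4ccc(Cl)cc4)cc3)cc2)CCN1c1ccncc1` gives > 1250 nM, a limit of the assay

Among the measured compounds shown here, compound 2 stands only as a limit in this assay; the two other values shown are limits as well, so no compound has a number here. For the measured compounds named here, the single step between measured compounds, a step that the two limits leave unreadable from compound 1 to compound 2, cannot be read because both ends are limits (the limit of > 12500 nM in this assay, at which 1 of the 3 values shown sits, (the limit of > 25000 nM in this assay, at which 1 of the 3 values shown sits)). Compound 3 sits at a further limit (the limit of > 1250 nM in this assay, at which 1 of the 3 values shown sits).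

Compound 4 `CCC(CCOc1ccc(-c2ccc(Cl)cc2)cc1)CCN1CCN(c2ccncc2)C1=O` differs from compound 2 by hydrogen in place of methyl on a saturated chain carbon, five bonds along the chain from an amide-type nitrogen in a ring and an oxygen on an aromatic ring. Going by the values given here, no measured step bears on this change, and nothing measured suggests a shift beyond the scatter in this assay. The expectation is therefore a step that the limit leaves unreadable from compound 2 to compound 4, and compound 4 is estimated at 30000 nM, within 12500 nM to 100000 nM, most likely reported again as a limit.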

Compound 4, half-maximal cytotoxic concentration: > 25000 nM
Compound 4: no number, only a limit; the forecaster's own chance of this, stated with the estimate: 80%; the middle value lies beyond the limit too.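

In this assay no new step can be read: compound 4 stands as a limit, as do compound 1 and compound 2, so its steps from both cannot be read. The compounds shown leave open whether any of these side-chain changes shifts the read-out at all.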